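Bulkier amide substituent and cytotoxicity on lung fibroblasts

The source may report more compounds than this note shows. Statements on the series, on what has been measured and on what is new or still open speak of the compounds shown alone.

Three compounds were measured in an ADME assay on MRC5 cells (Homo sapiens) for cytotoxicity, read by MTT assay, with a stated time of 4 h; a lower number here means that less compound is needed, a higher number that more compound is needed for the effect. Compound 1 `CC(C)(C)c1ccc(CC(CN)(Cc2ccc(C(C)(C)C)cc2)C(=O)NCCCN)cc1` gives 35000 nM. Compound 2 `NCCCNC(=O)C(CN)(Cc1ccc2ccccc2c1)Cc1ccc2ccccc2c1` gives 6600 nM, the lowest of the three numbers. Compound 3 `CC(C)(C)c1ccc(CC(CN)(Cc2ccc(C(C)(C)C)cc2)C(=O)N[C@@H](CCCNC(=N)N)C(N)=O)cc1` gives 158000 nM, the highest.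

Compound 3 differs from compound 1 in one place: a group of 11 heavy atoms (6 carbon, 4 nitrogen, 1 oxygen; no ring) in place of a group of 4 heavy atoms (3 carbon, 1 nitrogen; no ring), on an amide-type nitrogen This change raised the number, with a 4.5-fold higher number from compound 1 to compound 3 (0.65 log units; beyond the scatter). Compound 2 and compound 1 share the same general build but differ in a large part of the molecule; the difference between the two cores is not broken down here. What the two values show is that compound 2 sits well below compound 1.

Compound 4 `N=C(N)NCCC[C@H](NC(=O)C(CN)(Cc1ccc2ccccc2c1)Cc1ccc2ccccc2c1)C(N)=O` has not yet been measured. It stands to compound 2 as compound 3 stands to compound 1: a group of 11 heavy atoms (6 carbon, 4 nitrogen, 1 oxygen; no ring) in place of a group of 4 heavy atoms (3 carbon, 1 nitrogen; no ring), on an amide-type nitrogen The place is described in the same words for both pairs, so this is the same change, made on the core of compound 2 instead of the core of compound 1.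

Going by the values given here, with the earlier step of a 4.5-fold higher number from compound 1 to compound 3 (0.65 log units; beyond the scatter) as the only guide, the step from compound 2 to compound 4 in this assay is expected to be of similar size, a 4.2-fold higher number from compound 2 to compound 4 (0.63 log units; beyond the scatter), because compound 1 gives 35000 nM and compound 3 gives 158000 nM. The number for compound 4 is therefore estimated at 28000 nM, likely between 9000 nM and 90000 nM.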

Compound 4, half-maximal effective concentration: 552000 nM
The estimate for compound 4 lay 20-fold (1.29 log units) below the measured number; the whole stated range lies below it.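

In this assay, putting the larger group in place of 3-aminopropyl on the amide-type nitrogen gave an 84-fold higher number from compound 2 to compound 4 (1.92 log units; beyond the scatter), so the change raised the number on the core of compound 2 as well, but the size of the step did not carry over: the same change on two cores in this assay, a 4.5-fold higher number (0.65 log units; beyond the scatter) from compound 1 to compound 3 and an 84-fold higher number (1.92 log units; beyond the scatter) from compound 2 to compound 4, 19-fold (1.27 log units) apart, beyond the scatter of two such steps

Within these two pairs, then, the direction of the change held on both cores, while the step measured on one core proved a poor guide to the size of the step on the other. Going by these compounds alone, the two pairs do not show what in the cores sets the steps apart, nor whether either step is typical of the series, and with only two cores no rule for a third can be drawn from them.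

The compounds shown leave open how the number would move with a simple amine, a carboxylic acid or a longer chain on the amide-type nitrogen, and whether such groups would also give steps that differ between the core of compound 1 and the core of compound 2. They also leave open which part of the entering group accounts for the larger step on the core of compound 2.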